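Removing the Nitro Group from Compound 1

The source may report more compounds than this note shows. Statements on the series, on what has been measured and on what is new or still open speak of the compounds shown alone.

Measured in a functional assay on A549 cells (Homo sapiens) for inhibition, read by CCK-8 assay, with a stated time of 48 h; a higher number here means a weaker inhibitor, a lower number a stronger inhibitor:
- Compound 1, `COc1ccc(-c2cc3nccc(-c4cc(OC)c(OC)c(OC)c4)n3n2)cc1[N+](=O)[O-]`, is reported only as a limit, > 10000 nM.
- Compound 2, `COc1cc(-c2ccnc3cc(-c4ccc(C(C)(C)C)cc4)nn23)cc(OC)c1OC`, is likewise reported only as a limit, > 10000 nM.

Compound 1 therefore stands at the edge of what this assay can report rather than at a number, and the same holds for compound 2; on the values shown, neither can be ranked against the other, since (the limit of > 10000 nM in this assay, at which 2 of the 2 values shown sit).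

Compound 3, `COc1ccc(-c2cc3nccc(-c4cc(OC)c(OC)c(OC)c4)n3n2)cc1`, has not yet been measured. It differs from compound 1 by hydrogen in place of nitro on an aromatic carbon. Within the data shown here, no step between two measured compounds is available to gauge what this change does in this assay, and the two limits above give no direction. The step is expected to be small, a step that the limit leaves unreadable from compound 1 to compound 3, with no movement beyond the scatter that the data would support. Compound 3 is accordingly expected to remain at or near the limit, with an estimate of 12000 nM and a range from 3000 nM to 50000 nM.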

Compound 3, half-maximal inhibitory concentration: 376 nM
Estimate against measurement, compound 3: 32-fold (1.50 log units) above, outside the stated range (below it).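

In this assay, replacing the nitro group with hydrogen gives an at least 26-fold lower number from compound 1 to compound 3 (1.42 log units; beyond the scatter), which shows that this aromatic carbon, ortho to a methoxy group, matters greatly: the nitro compound had given no sign of this while it sat at the limit alone. Compound 2 adds a second reading, since methoxy in place of tert-butyl on an aromatic carbon gives an at least 26-fold lower number from compound 2 to compound 3 (1.42 log units; beyond the scatter), so the activity of compound 3 is lost with a change at either of these two places on that ring. Both steps are minimum sizes rather than measured ones, and how far each truly reaches cannot be told because the starting compounds stand at a limit and not at a number: the limit of > 10000 nM in this assay, at which 2 of the 3 values shown sit.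

The compounds shown leave open whether it is the nitro group in particular that costs so much, or whether an amine, a fluorine atom or a hydroxyl group on the same carbon would stay close to compound 3 at 376 nM. They also leave open how much the remaining methoxy group itself contributes, and whether an ethoxy group or a plain hydrogen could stand in its place.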